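Hydroxy for methyl ortho to the ketone

The compounds below may be only part of what the source reports. "The series", "measured", "known", "first", "only" and "open" are said of these compounds alone.

Measured so far in an assay on HEK293 cells for positive allosteric modulation of metabotropic glutamate receptor 2 (Rattus norvegicus), read by thallium flux, with a stated time of 2.5 min; a higher number here means a larger maximal response, a lower number a smaller maximal response:
compound 1 `COc1ccc(C(=O)O)cc1OCCCCOc1ccc(C(=O)CC2CCCC2)c(O)c1C`: 91.8%
compound 2 `Cc1c(OCCCCOc2ccc(F)c(C(=O)O)c2)ccc(C(=O)CC2CCCC2)c1C`: 14.6%
compound 3 `Cc1c(OCCCCOc2cccc(C(=O)O)c2)ccc(C(=O)CC2CCCC2)c1C`: 22.4%

Compound 2 stands lowest of the three numbers in this assay; compound 3 is nearest and compound 1 farthest. Going by the values given here, the one measured step, a number 7.8 percentage points higher from compound 2 to compound 3 (within the scatter), is within the scatter and concerns a different place. Compound 4 `Cc1c(OCCCCOc2ccc(F)c(C(=O)O)c2)ccc(C(=O)CC2CCCC2)c1O` arises from compound 2 by hydroxy in place of methyl on an aromatic carbon. Among the compounds with values here, no measured step tests this change directly. Compound 1 also bears a hydroxy ortho to the (cyclopentylmethyl)carbonyl group but differs from compound 2 in other places too; in this assay compound 1 gives 91.8%. On that support a rise is expected from compound 2 to compound 4, a number 40.4 percentage points higher from compound 2 to compound 4 (beyond the scatter), with a wide range. In this assay compound 4 is estimated at 55% (25% to 90%).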

Compound 4, largest response reached (reported as percent of maximum), in percent of the reference or control that the assay uses: 81%
Beside the measured number, compound 4's estimate is 26 percentage points below it; measured number inside the range.
By their numbers in this assay, from the lowest: compounds 2 and 3 (each within the scatter of the next); then compound 4; then compound 1.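

In this assay, hydroxy in place of methyl on this aromatic carbon, ortho to the (cyclopentylmethyl)carbonyl group, now has a direct test: a number 66.4 percentage points higher from compound 2 to compound 4 (beyond the scatter), a large step. With the hydroxy held, 3-carboxy-4-fluorophenyl in place of 5-carboxy-2-methoxyphenyl gives a modest step, a number 10.8 percentage points lower from compound 1 to compound 4 (beyond the scatter), much smaller than the step at this position. As far as these compounds go, whether an amine or a methoxy on this carbon would match the hydroxy remains open. No measurement shown gives a reason for the rise.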